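Removing the amino group from compound 3

The source may report more compounds than this note shows. Statements on the series, on what has been measured and on what is new or still open speak of the compounds shown alone.

Measured so far:
compound 1 `C=CC(=O)Nc1ccnc(Sc2c(C)nc(N3CCN(C)CC3)nc2C)n1` — 5000 nM
compound 2 `C=CC(=O)Nc1cc(N)nc(Sc2c(OC)nc(N3CCCCC3)nc2OC)n1` — 5000 nM
compound 3 `C=CC(=O)Nc1cc(N)nc(Sc2c(OC)nc(N3CCN(C)CC3)nc2OC)n1` — 2000 nM

In a functional assay on SK-BR-3 cells (Homo sapiens) for activation, read by Western blot (a higher number here means a weaker inhibitor, a lower number a stronger inhibitor), compound 3 gives the lowest of the three numbers, a step of a 2.5-fold lower number from compound 2 to compound 3 (0.40 log units; beyond the scatter) from compound 2. Compound 4 `C=CC(=O)Nc1ccnc(Sc2c(OC)nc(N3CCN(C)CC3)nc2OC)n1` differs from compound 3 by hydrogen in place of amino on an aromatic carbon. Among the compounds with values here, no measured step covers this change. Compound 1, which also carries no amino group, gives 5000 nM in this assay, but it differs from compound 4 in other places as well, so it gives only a loose hint. Compound 4 is therefore expected to give a somewhat higher number than compound 3, a step of about a 2.0-fold higher number from compound 3 to compound 4 (0.30 log units; within the scatter), with wide uncertainty. The estimate for compound 4 is 4000 nM, in a range from 1500 nM to 12000 nM.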

Compound 4, half-maximal inhibitory concentration: 7500 nM
Compound 4: middle estimate off by 1.9-fold (0.27 log units), on the low side; the range from low to high includes it.
By their numbers in this assay, from the lowest: compound 3; then compounds 1, 2 and 4 (each within the scatter of the next).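

In this assay the amino group proves to count for something: with hydrogen in its place there is a 3.8-fold higher number from compound 3 to compound 4 (0.57 log units; beyond the scatter) and the step lies beyond the scatter. Within the data shown here, this is the only measured change at this position, next to the ring nitrogen, and it links the amino group with the stronger inhibitor in this one pair. Nothing measured here gives a reason for the step.

Going by these compounds, whether a methylamino group or a fluorine at this position would match the amino group remains open. So does whether removing the amino group would matter as much with piperidin-1-yl in place of 4-methylpiperazin-1-yl.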